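The source may hold more compounds than are shown below. What is called first, only, known or untested is meant among the compounds shown, and "the series" means these compounds.

Measured in an in vitro ADME assay on microsomes from liver (Homo sapiens) for metabolic stability, using NADPH; a higher number here means faster removal of the compound, a lower number slower removal:
- Compound 1 `CC(C)(CO)CNC(=O)c1cc2cc(C#N)ccc2n1Cc1cccc(OC(F)(F)F)c1`: 62 mL.min-1.g-1
- Compound 2 `COc1ccc(OC(F)(F)F)cc1Cn1c(C(=O)NCC(C)(C)CO)cc2cc(C#N)ccc21`: 69 mL.min-1.g-1
- Compound 3 `CCOc1ccc(OC(F)(F)F)cc1Cn1c(C(=O)NCC(C)(C)CO)cc2cc(C#N)ccc21`: 103 mL.min-1.g-1

Compound 1 stands level with the other two compounds in this assay: the data show a 1.1-fold higher number from compound 1 to compound 2 (0.05 log units; within the scatter) and a 1.7-fold higher number from compound 1 to compound 3 (0.22 log units; within the scatter). Between the two substituted compounds, the data show a 1.5-fold higher number from compound 2 to compound 3 (0.17 log units; within the scatter).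

Compound 4 `CC(C)(O)CCNC(=O)c1cc2cc(C#N)ccc2n1Cc1cccc(OC(F)(F)F)c1` has the same atoms as compound 1, joined differently in the chain on the amide-type nitrogen: 2-hydroxy-2-methylpropyl in place of 1-(hydroxymethyl)-1-methylethyl on a saturated chain carbon bound to an amide-type nitrogen. This reads as (3-hydroxy-3-methylbutyl)carbamoyl replacing (2-(hydroxymethyl)-2-methylpropyl)carbamoyl.

Within the data shown here, none of the measured steps alters this chain. Among the measured compounds shown here, all three concern the substituent on the aromatic carbon, so they show only the level of the series and the data hold no direct precedent for this change. No step beyond the scatter is therefore expected, and the estimated step is a 1.1-fold lower number from compound 1 to compound 4 (0.03 log units; within the scatter). The value expected for compound 4 is 58 mL.min-1.g-1, with an estimated range from 28 mL.min-1.g-1 to 115 mL.min-1.g-1.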

Compound 4, intrinsic clearance in microsomes: 9 mL.min-1.g-1
For compound 4 the middle estimate is 6.4-fold (0.81 log units) above the measured one, outside the stated range (below it).
By their numbers in this assay, from the lowest: compound 4; then compounds 1, 2 and 3 (each within the scatter of the next).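

Among these compounds, the chain on the amide-type nitrogen is the first place where this assay moves beyond the scatter: 3-hydroxy-3-methylbutyl in place of 2-(hydroxymethyl)-2-methylpropyl gives a 6.9-fold lower number from compound 1 to compound 4 (0.84 log units; beyond the scatter) and leaves the rest of the molecule unchanged. The two chains have the same atoms and match in heavy atoms, hydrogen-bond donors and acceptors, so the way those atoms are joined is enough to shift the read-out, whereas the aromatic substituents in compounds 1, 2 and 3 stayed within the scatter. Nothing available bears on why this rearrangement has such an effect.

As far as these compounds go, it remains open whether the same chain gives a comparable step on the methoxy and ethoxy compounds, compound 2 and compound 3. From the compounds shown here alone, how this assay would read with an amine or a carboxylic acid in place of the hydroxyl, or with a longer chain, also remains open.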